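The source may hold more compounds than are shown below. What is called first, only, known or untested is meant among the compounds shown, and "the series" means these compounds.

Compound 1 `Cc1nc(SCC(=O)Nc2nc(-c3ccc(Cl)cc3)cs2)n(Nc2ccccc2)c1C`: 14100 nM
Compound 2 `Cc1ccc(Nn2c(SCC(=O)Nc3nc(-c4ccccc4)cs3)nc(C)c2C)cc1`: 62900 nM

In a functional assay on ACHN cells (Homo sapiens) for antiproliferative activity, read by sulforhodamine B assay, with a stated time of 48 h (a lower number here means a stronger inhibitor of growth, a higher number a weaker inhibitor of growth), compound 1 gives 14100 nM, the lowest of the two numbers, and in this assay compound 2 gives 62900 nM, a higher number that lies beyond the usual scatter. Compound 3 `COc1ccc(Nn2c(SCC(=O)Nc3nc(-c4ccc(Cl)cc4)cs3)nc(C)c2C)cc1` differs from compound 1 in one place: methoxy in place of hydrogen on an aromatic carbon. Going by the values given here, no pair of measured compounds shows this change on its own, so its size is not known from measurement; a small step toward a higher number, or none beyond the scatter, is expected. Compound 3 is therefore estimated at 20000 nM, in a range from 6000 nM to 60000 nM. The expected step is a 1.4-fold higher number from compound 1 to compound 3 (0.15 log units; within the scatter).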

Compound 3, concentration for total growth inhibition: 8760 nM
For compound 3 the middle estimate is 2.3-fold (0.36 log units) above the measured one; the range from low to high includes it.
By their numbers in this assay, from the lowest: compounds 3 and 1 (each within the scatter of the next); then compound 2.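

In this assay, placing methoxy on the aromatic carbon para to a large group gives a 1.6-fold lower number from compound 1 to compound 3 (0.21 log units; within the scatter), a step within the usual scatter. This position of the anilino ring therefore takes the methoxy group with no measurable change in growth inhibition, which compounds 1 and 2 alone could not show. No available evidence bears on why this is so. Going by these compounds, it remains open whether an amine, a carboxylic acid or a longer chain at this carbon would leave the number equally unchanged. Methoxy on another carbon of this ring is also untested here.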